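The source may hold more compounds than are shown below. What is called first, only, known or untested is meant among the compounds shown, and "the series" means these compounds.

Compound 1 `Nc1nc(NCCNc2ncc(-c3ncc[nH]3)c(-c3ccccc3Br)n2)ccc1[N+](=O)[O-]`: in an ADME assay on microsomes from liver (Rattus norvegicus) for metabolic stability (a lower number here means that the compound disappears faster, a higher number that the compound lasts longer), compound 1 gives > 0.5 h, a limit.
Compound 2 `Nc1nc(NCCNc2ncc(-c3ncc[nH]3)c(-c3cc(F)c(Cl)cc3F)n2)ccc1[N+](=O)[O-]`: in this assay, compound 2 gives > 0.5 h, a limit.

Compound 2 therefore has no number, and its position is the limit of > 0.5 h in this assay, at which 2 of the 2 values shown sit. Compound 3 `Cc1ccc(-c2nc(NCCNc3ccc([N+](=O)[O-])c(N)n3)ncc2-c2ncc[nH]2)c(Br)c1` differs from compound 2 as follows: 2-bromo-4-methylphenyl in place of 4-chloro-2,5-difluorophenyl on an aromatic carbon. Among the compounds with values here, the one measured step is a step that the two limits leave unreadable from compound 1 to compound 2, so no size carries over to this change. No step beyond the scatter is expected in this assay, and no direction is favoured. The expected step is a step that the limit leaves unreadable from compound 2 to compound 3. The estimate for compound 3 is 0.7 h, with an expected range of 0.3 h to 1.5 h.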

Compound 3, half-life: > 0.5 h
Compound 3 gave a limit, no number; the forecaster's own chance of this, stated with the estimate: 70%; the middle value lies beyond the limit too.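

Compound 1, compound 2 and compound 3 each give only a limit in this assay, so no step among them can be read: the limit of > 0.5 h in this assay, at which 3 of the 3 values shown sit.

From the compounds shown here alone, how far each compound lies past that limit, and whether these aryl changes shift the half-life at all, stays open.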